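This account rests on a few compounds, and the source may have more. Where it says the series, first, only, none or still open, it means among the compounds named here.

Compound 1 `O=C(CN(c1nc(Cl)nc2[nH]cnc12)C1CC1)N[C@@H](CO)C(=O)OCc1ccccc1`: 34.5%
Compound 2 `NC(=O)CC[C@H](NC(=O)CN(c1ncnc2c1ncn2C1CCCCO1)C1CC1)C(=O)OCc1ccccc1`: 22.3%

Of the compounds shown here, two have so far been tested in a functional assay on the whole organism (Tail, strain ICR) with Mus musculus as the target, in the tail flick test, with a stated time of 120 min, at a dose of 25 umol/kg by the oral route; a higher number here means a stronger effect of the compound at the dose given, a lower number a weaker effect. Compound 1 gives 34.5%, the higher of the two numbers. Compound 2 gives 22.3%, and the gap between these two values lies beyond the usual scatter of repeated measurements of this kind. The two compounds differ from each other in several places at once, so no single structural change can be tied to that gap.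

Compound 3 `C[C@H](NC(=O)CN(c1nc(Cl)nc2[nH]cnc12)C1CC1)C(=O)OCc1ccccc1` has not yet been tested. It keeps the core of compound 1 and differs from it in a single place: hydrogen in place of hydroxy on a saturated chain carbon, two bonds along the chain from an amide-type nitrogen and a carbonyl carbon. Going by the values given here, no measured pair of compounds shows a change of this kind, so the expectation rests on the one value of compound 1 alone. A small step is expected, a number 4.5 percentage points lower from compound 1 to compound 3 (within the scatter), one that may well stay within the scatter. On that basis compound 3 is estimated to reach 30% in this assay, with a range from 12% to 50%.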

Compound 3, a percentage reported as activity, at one dose (the size of the read-out at that dose, not a potency): 36.1%
Estimate against measurement, compound 3: 6.1 percentage points below; measured number inside the range.
By their numbers in this assay, from the lowest: compound 2; then compounds 1 and 3 (each within the scatter of the next).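

In this assay, going by these compounds alone, the change from hydroxymethyl to methyl gives a number 1.6 percentage points higher from compound 1 to compound 3 (within the scatter) and so marks the first comparison that can be tied to one structural change. The hydroxy group on this saturated chain carbon, two bonds along the chain from an amide-type nitrogen and a carbonyl carbon, can therefore be replaced by hydrogen without a difference that stands out from the scatter at this dose and time. Nothing in the available data explains why the two numbers lie so close together.

On these data alone, a reading at one dose gives the size of the effect at that dose only, so it remains open whether compound 1 and compound 3 would also stay within the scatter of each other at other doses or times. As far as these compounds go, it also remains open how this chain position would respond to other groups, such as an amine, a carboxylic acid or a longer chain, since this pair speaks only for the change from hydroxymethyl to methyl.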